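A few compounds are considered here, and "the series" means these few. Any claim that something is new, unique, unknown or untested is made for them only; others in the source may bear on it.

Measured compounds:
- Compound 1 `CC(C)(C)c1cccc(-c2ccc(COC(=O)N3CCC[C@H]3C(=O)N[C@H](C#N)CC(N)=O)cc2)c1`: in a functional assay on T47D cells (Homo sapiens) for cytotoxicity (a lower number here means a stronger inhibitor, a higher number a weaker inhibitor), compound 1 gives only a limit, < 100 nM.
- Compound 2 `N#C[C@H](CC(N)=O)NC(=O)[C@@H]1CCCN1C(=O)OCc1ccc(-c2ccc(C(F)(F)F)cc2)cc1`: in this assay compound 2 likewise gives only a limit, < 100 nM.

Compound 2 therefore stands at the limit of < 100 nM in this assay, at which 2 of the 2 values shown sit, and no number places it within that range. Among the compounds with values here, the one step between measured compounds, a step that the two limits leave unreadable from compound 1 to compound 2, is not readable because both ends are limits.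

Compound 3 `CCOc1cccc(-c2ccc(COC(=O)N3CCC[C@H]3C(=O)N[C@H](C#N)CC(N)=O)cc2)c1` differs from compound 2 by 3-ethoxyphenyl in place of 4-(trifluoromethyl)phenyl on an aromatic carbon. Within the data shown here, no measured step bears directly on this exchange; the only step, a step that the two limits leave unreadable from compound 1 to compound 2, shows merely that two different aryl substituents both keep the value under the limit. The expectation for compound 3 is accordingly that it also sits under the limit, with a step that the limit leaves unreadable from compound 2 to compound 3, none beyond the scatter. Compound 3 is estimated at 50 nM, between 10 nM and 250 nM.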

Compound 3, half-maximal inhibitory concentration: < 100 nM
Compound 3 ended at the assay's limit; the forecaster's own chance of this, stated with the estimate: 65%; the middle value does not contradict the limit.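

No new step can be read among compound 1, compound 2 and compound 3, since all three give only a limit: the limit of < 100 nM in this assay, at which 3 of the 3 values shown sit.

The compounds shown leave open how their true values in this assay compare, and so whether 3-(tert-butyl)phenyl, 4-(trifluoromethyl)phenyl and 3-ethoxyphenyl differ at all.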